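Swapping Piperazine for Pyrrolidine: Expected Solubility Shift

This account rests on a few compounds, and the source may have more. Where it says the series, first, only, none or still open, it means among the compounds named here.

Of the compounds shown here, two have been measured in a physicochemical assay for solubility, measured as kinetic solubility; on this read-out higher numbers stand for higher solubility and lower numbers for lower solubility. Compound 1, with the structure `N#Cc1cccc(NC(=O)c2cc(C(F)(F)F)ccc2OCc2ccc(F)cc2)c1`, gives < 1000 nM in this assay, and this is a limit of the assay rather than a number. Of the two values shown, one sits at the limit of < 1000 nM in this assay, at which 1 of the 2 values shown sits. Going by the values given here, compound 2, with the structure `O=C(Nc1ccnnc1)c1cc(N2CCNCC2)ccc1OCc1ccccc1`, gives 98000 nM in this assay, the only actual number among the values shown, so there is no measured step against which to compare it.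

Compound 3, with the structure `O=C(Nc1ccnnc1)c1cc(N2CCCC2)ccc1OCc1ccccc1`, has not yet been measured in this assay. It differs from compound 2 in one place: pyrrolidin-1-yl in place of piperazin-1-yl on an aromatic carbon. Among the compounds with values here, no pair of measured compounds shows what this kind of change does in this assay, so any expectation rests on the values above alone. The change is expected to lower solubility by a moderate step, beyond the usual scatter, with the step from compound 2 to compound 3 estimated as a 6.5-fold lower number from compound 2 to compound 3 (0.82 log units; beyond the scatter). Compound 3 is therefore estimated at 15000 nM, with a range from 3000 nM to 60000 nM.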

Compound 3, solubility: 35000 nM
Compound 3: middle estimate off by 2.3-fold (0.37 log units), on the low side; the measured number falls inside the stated range.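

Going by these compounds alone, replacing piperazin-1-yl with pyrrolidin-1-yl, on the aromatic carbon para to a benzyloxy group, gives the first single-change comparison in this assay: a 2.8-fold lower number from compound 2 to compound 3 (0.45 log units; beyond the scatter). This shows that the read-out responds to the group at this position, although compound 3 still gives a measured number, 35000 nM, and not a limit of the assay. The entering ring has 1 hetero atom and 0 hydrogen-bond donors, against 2 hetero atoms and 1 hydrogen-bond donor in the leaving ring, but no measurement shown links the step to either difference or to any other cause.

A single pair cannot separate the roles of the ring size, the second ring nitrogen and its hydrogen, so a morpholine ring, a piperidine ring or an open-chain group such as dimethylamino at the same position would be informative comparisons. Going by these compounds, it also remains open whether the same swap would produce a step of similar size on a different core, or with a group other than the (pyridazin-4-yl)carbamoyl group on the shared ring.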